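The source may report more compounds than this note shows. Statements on the series, on what has been measured and on what is new or still open speak of the compounds shown alone.

Three compounds with a shared core have numbers in a functional assay on HepG2 cells (Homo sapiens) for antiproliferative activity, read by MTT assay; on this read-out lower numbers stand for stronger inhibition and higher numbers for weaker inhibition. Compound 1 (`Nc1c(C(=O)N/N=C/c2ccccc2)oc2nc(-c3cccs3)cc(C(F)(F)F)c12`) gives 9900 nM, compound 2 (`Nc1c(C(=O)N/N=C/c2ccc(Cl)cc2)oc2nc(-c3cccs3)cc(C(F)(F)F)c12`) gives 8100 nM, and compound 3 (`Nc1c(C(=O)N/N=C/c2ccc(Cl)cc2)oc2nc(-c3ccccc3)cc(C(F)(F)F)c12`) gives 12100 nM. Compound 2 stands within the scatter of both of the others. The step of a 1.2-fold lower number from compound 1 to compound 2 (0.09 log units; within the scatter) puts chloro in place of hydrogen on an aromatic carbon, and the step of a 1.5-fold higher number from compound 2 to compound 3 (0.17 log units; within the scatter) puts phenyl in place of thiophen-2-yl on an aromatic carbon. Both steps are small.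

Compound 4 (`Nc1c(C(=O)NC2CCCC2)oc2nc(-c3cccs3)cc(C(F)(F)F)c12`) has not yet been measured. It differs from compound 2 on an amide-type nitrogen, where cyclopentyl enters: a group of 5 heavy atoms (5 carbon; one five-membered non-aromatic ring of carbon only) in place of a group of 9 heavy atoms (7 carbon, 1 nitrogen, 1 chlorine; one six-membered aromatic ring of carbon only), on an amide-type nitrogen. The measured steps offer little guidance for this change. The step of a 1.2-fold lower number from compound 1 to compound 2 (0.09 log units; within the scatter) touches the departing group only through its chloro, and the step of a 1.5-fold higher number from compound 2 to compound 3 (0.17 log units; within the scatter) lies elsewhere in the structure. For the measured compounds named here, no measured compound carries cyclopentyl, so the data favour no direction, and no step beyond the scatter is expected in this assay, although the uncertainty is wide. The expected step is a 1.4-fold higher number from compound 2 to compound 4 (0.13 log units; within the scatter). For compound 4 the estimated value is 11000 nM, with an expected range of 3500 nM to 35000 nM.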

Compound 4, half-maximal inhibitory concentration: 20800 nM
Compound 4: the middle estimate sits 1.9-fold (0.28 log units) below what was measured, and the stated range covers the measured number.
By their numbers in this assay, from the lowest: compounds 2, 1, 3 and 4 (each within the scatter of the next, the first and the last beyond it).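

Replacing the group on the amide-type nitrogen with cyclopentyl moves the number in this assay beyond the scatter: the step of a 2.6-fold higher number from compound 2 to compound 4 (0.41 log units; beyond the scatter) and the step of a 2.1-fold higher number from compound 1 to compound 4 (0.32 log units; beyond the scatter) both point the same way, towards weaker inhibition. The chloro and thiophen-2-yl changes stayed within the scatter, so this amide-type nitrogen is the only one of the three places shown where a change has had a step beyond it, and that holds whether or not the departing group carries chloro. Nothing available gives a reason for this step.

The compounds shown leave open which part of the departing group counts, since its six-membered aromatic ring, its double bond and its nitrogen all leave together in this one exchange, and cyclopentyl is the only replacement on this nitrogen. Going by these compounds, a cyclohexyl ring, a benzyl group or an n-butyl chain on the same nitrogen would help separate ring size, aromatic character and chain from one another, and it also remains open whether cyclopentyl would give a similar step with phenyl on the core in place of thiophen-2-yl.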